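The source may hold more compounds than are shown below. What is called first, only, known or untested is meant among the compounds shown, and "the series" means these compounds.

Measured compounds in an ADME assay on cells (Hepatocyte, Rattus norvegicus) for pharmacokinetics; on this read-out higher numbers stand for fast clearance and lower numbers for slow clearance:
- compound 1 `Cc1ccc(S(=O)(=O)c2cc(F)c(O)c3ncccc23)cc1`: 36 uL/min
- compound 2 `O=S(=O)(c1cc(F)c(O)c2ncccc12)C1CCCC1`: 19 uL/min

Compound 2 carries the lowest number of the two in this assay; its nearest neighbour is compound 1, and the step of a 1.9-fold lower number from compound 1 to compound 2 (0.28 log units; within the scatter) lies within the scatter, so the two cannot be ordered against each other.

Compound 3 `O=S(=O)(c1cc(F)c(O)c2ncccc12)N1CCCC1` is not yet measured. It differs from compound 2 as follows: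
pyrrolidin-1-yl in place of cyclopentyl on a sulfonyl sulfur

Going by the values given here, only one measured step bears on this change, and only loosely: a 1.9-fold lower number from compound 1 to compound 2 (0.28 log units; within the scatter) replaced one group on the sulfonyl sulfur with another and produced nothing beyond the scatter. Among the compounds with values here, no measured pair shows the exchange of cyclopentyl for pyrrolidin-1-yl itself, so there is no direct precedent for the size or direction of its effect in this assay.

With a single neighbouring step that stayed within the scatter, the expectation for compound 3 is a number close to that of compound 2, with the step of a 1.2-fold lower number from compound 2 to compound 3 (0.07 log units; within the scatter) expected to remain within the scatter. Compound 3 is therefore estimated at 16 uL/min in this assay, in a range from 6 uL/min to 38 uL/min.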

Compound 3, intrinsic clearance in a liver preparation (reported as CLH), per the amount of preparation that the assay uses: 21 uL/min
For compound 3 the middle estimate is 1.3-fold (0.12 log units) below the measured one; low and high end bracket the measured number.
By their numbers in this assay, from the lowest: compounds 2, 3 and 1 (each within the scatter of the next).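

In this assay, going by these compounds alone, pyrrolidin-1-yl in place of cyclopentyl on a sulfonyl sulfur gives a 1.1-fold higher number from compound 2 to compound 3 (0.04 log units; within the scatter) and is the first direct reading of this exchange: with the ring size kept, a ring with one nitrogen and a ring of carbon only cannot be told apart on this read-out. Within the data shown here, measured against the 4-methylphenyl group, the same position gives a 1.7-fold lower number from compound 1 to compound 3 (0.23 log units; within the scatter), so compound 1, compound 2 and compound 3 now form a set of three groups on the sulfonyl sulfur, aromatic and non-aromatic, with no step among them leaving the scatter and no order among them. The data in hand offer nothing that accounts for this flat picture.

Open, going by these compounds, is whether any group on this sulfur moves the number beyond the scatter at all, for instance a morpholine, a group carrying a carboxylic acid or an amine, or a longer alkyl chain. Also open, on these data alone, is whether changes on the shared core, which all three compounds hold in common, would shift the number more than changes on the sulfur do.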